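This account rests on a few compounds, and the source may have more. Where it says the series, first, only, none or still open, it means among the compounds named here.

Measured in an ADME assay on L1210/0 cells (Mus musculus) for cytotoxicity, with a stated time of 48 h; a lower number here means a stronger inhibitor, a higher number a weaker inhibitor:

- compound 1, `N#CSc1cn([C@H]2C[C@H](O)[C@@H](CO)O2)c(=O)[nH]c1=O`: 78900 nM
- compound 2, `O=C(CI)NCc1cn([C@H]2C[C@H](O)[C@@H](CO)O2)c(=O)[nH]c1=O`: 107000 nM
- compound 3, `O=c1[nH]c(=O)n([C@H]2C[C@H](O)[C@@H](CO)O2)cc1C#Cc1ccccc1`: > 200000 nM, a limit of the assay rather than a number

Compound 3 stands at the edge of what this assay reports: the limit of > 200000 nM in this assay, at which 1 of the 3 values shown sits. The two steps that run toward compound 3 are an at least 2.5-fold higher number from compound 1 to compound 3 (0.40 log units; beyond the scatter) and an at least 1.8-fold higher number from compound 2 to compound 3 (0.27 log units; that floor lies within the scatter); the first lies beyond the scatter, the second has a floor inside it. Compound 1 and compound 2 sit close to each other, a 1.4-fold higher number from compound 1 to compound 2 (0.13 log units; within the scatter).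

The next compound, compound 4, is `CCCCCCc1cn([C@H]2C[C@H](O)[C@@H](CO)O2)c(=O)[nH]c1=O`. The change from compound 3: hexyl in place of 2-phenylethynyl on an aromatic carbon. Within the data shown here, no measured step involves a hexyl group, and no measured step leaves compound 3 toward a smaller substituent, so the expectation rests only on where compound 3 stands and on the range of compounds 1 and 2 in this assay.

Compound 4 is expected to remain a weak inhibitor, with the step of an at least 1.3-fold lower number from compound 3 to compound 4 (0.12 log units; that floor lies within the scatter) taken as an estimate from a limit, so its sign is uncertain. The estimate for compound 4 is 150000 nM, in the range 40000 nM to 500000 nM, with a fair chance that this assay again returns only a limit.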

Compound 4, half-maximal inhibitory concentration: > 200000 nM
Compound 4: a limit, no number; the forecaster's own chance of this, stated with the estimate: 45%; middle value at least 1.3-fold (0.12 log units) away from the limit.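

In this assay compound 4 also returns only a limit, > 200000 nM, so a hexyl chain on this aromatic carbon, with no ring and no triple bond, ends at the same assay edge as the 2-phenylethynyl group: the limit of > 200000 nM in this assay, at which 2 of the 4 values shown sit.

The step from compound 3 to compound 4 joins two limits and cannot be read. Against the two compounds with numbers, the result is an at least 2.5-fold higher number from compound 1 to compound 4 (0.40 log units; beyond the scatter) and an at least 1.8-fold higher number from compound 2 to compound 4 (0.27 log units; that floor lies within the scatter); only the first of these lies beyond the scatter.

On these data alone, how far compound 3 and compound 4 lie past the limit remains open, and with it whether hexyl and 2-phenylethynyl differ at all. Also open, as far as these compounds go, is whether a shorter chain such as ethyl, or a chain ending in an amine, would give a readable number at this position.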